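Estimating compound 4 after a side-group exchange

The compounds below may be only part of what the source reports. "The series", "measured", "known", "first", "only" and "open" are said of these compounds alone.

In a physicochemical assay for lipophilicity, read by HPLC, at pH 7.5 (a higher number here means a more lipophilic compound, a lower number a more polar compound), compound 2 `CCOc1ccccc1-c1ccc(-c2nc3cnccc3c(N[C@H](CC)C(=O)NS(C)(=O)=O)c2C#N)cc1` reads 2.2 and is the lowest of the three measured compounds, clearly under both compound 1 `CC[C@@H](Nc1c(C#N)c(-c2ccc(-c3ccc(F)cc3)cc2)nc2cnccc12)C(N)=O` and compound 3 `CC[C@@H](Nc1c(C#N)c(-c2ccc(-c3ccc(Cl)cc3)cc2)nc2cnccc12)C(N)=O` on that scale. The change to compound 4 `CCOc1ccccc1-c1ccc(-c2nc3cnccc3c(NC(C(N)=O)C3CC3)c2C#N)cc1` is this: a group of 7 heavy atoms (5 carbon, 1 nitrogen, 1 oxygen; one three-membered non-aromatic ring of carbon only) in place of a group of 10 heavy atoms (5 carbon, 1 nitrogen, 3 oxygen, 1 sulfur; no ring), on a nitrogen on an aromatic ring and the rest of the structure stays the same.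

Within the data shown here, no measured step tests this exchange directly. The only one, a number 0.40 log units higher from compound 1 to compound 3 (beyond the scatter) for chloro in place of fluoro on an aromatic carbon, is a different kind of change and serves only as a sense of scale. The closer guide is the group on that nitrogen in the other two compounds, which holds no sulfur, as in compound 4. Compound 1 at 2.7 and compound 3 at 3.1 both stand above compound 2 and carry such a group. An upward move beyond the scatter is therefore expected, with the estimated step being a number 0.80 log units higher from compound 2 to compound 4 (beyond the scatter) in this assay for this exchange. For compound 4 the estimated value is 3 with an expected range from 2.5 to 3.5 as the likely span.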

Compound 4, distribution coefficient: 3
For compound 4 middle estimate and measured number coincide at the digits printed; the measured number falls inside the stated range.
By their numbers in this assay, from the lowest: compound 2; then compounds 1, 4 and 3 (each within the scatter of the next, the first and the last beyond it).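

In this assay, among these compounds, the exchange on this nitrogen gives a number 0.80 log units higher from compound 2 to compound 4 (beyond the scatter) with the rest of the structure held the same, the first measured step at this position. It shows that the reading depends on the group placed here, and not only on the chloro and fluoro change elsewhere in the molecule. The exchange alters several things at once, since sulfur leaves, a three-membered non-aromatic ring of carbon only enters, and the count of hydrogen-bond acceptors falls, and no measurement on hand explains the rise or assigns it to any one of these features.

Whether the ring or the loss of sulfur accounts for the step remains open. So does how this assay would read with a carboxylic acid, an amine or a longer chain in this place.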